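Notes on amide series: fluoro for trifluoromethyl

A few compounds are considered here, and "the series" means these few. Any claim that something is new, unique, unknown or untested is made for them only; others in the source may bear on it.

Of the compounds shown here, three have been measured in an assay on CHO cells for displacement of a labelled ligand from adenosine receptor A3 (Homo sapiens), read by scintillation counting, with a stated time of 3 h; on this read-out lower numbers stand for stronger inhibition and higher numbers for weaker inhibition.
Compound 1 `Cn1cc2c(Cl)nc(NC(=O)c3ccc(C(F)(F)F)cc3)nc2n1` gives 33500 nM.
Compound 2 `Cn1cc2c(Cl)nc(NC(=O)c3ccc(F)cc3)nc2n1` gives 31900 nM.
Compound 3 `CC(C)n1cc2c(Cl)nc(NC(=O)c3ccc(C(F)(F)F)cc3)nc2n1` gives 10300 nM.

Compound 4 `CC(C)n1cc2c(Cl)nc(NC(=O)c3ccc(F)cc3)nc2n1` is not yet measured. It differs from compound 3 by fluoro in place of trifluoromethyl on an aromatic carbon. This change has been made once before in the set: fluoro in place of trifluoromethyl on an aromatic carbon gave a 1.1-fold lower number from compound 1 to compound 2 (0.02 log units; within the scatter). The two cores differ by isopropyl in place of methyl on an aromatic nitrogen, which gave a 3.3-fold lower number from compound 1 to compound 3 (0.51 log units; beyond the scatter) in this assay. The place of the change is described in the same words in both pairs, so it is the same change. Compound 3 stands lowest of the three measured numbers, both other compounds lying beyond the scatter from it.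

For compound 4 in this assay a step of a 1.1-fold lower number from compound 3 to compound 4 (0.04 log units; within the scatter) is expected. This rests on a 1.1-fold lower number from compound 1 to compound 2 (0.02 log units; within the scatter), which lay within the scatter. Compound 4 is estimated at 9500 nM, between 4500 nM and 20000 nM.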

Compound 4, inhibition constant: > 60000 nM
Compound 4: a limit, no number; the forecaster's own chance of this, stated with the estimate: 5%; middle value at least 6.3-fold (0.80 log units) from the limit.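

In this assay compound 4 gives > 60000 nM, which is a limit of the assay and not a number.
Fluoro in place of trifluoromethyl gave an at least 5.8-fold higher number from compound 3 to compound 4 (0.76 log units; beyond the scatter), so the step seen on the core of compound 1 did not carry over to the core of compound 3: the same change on two cores in this assay, a 1.1-fold lower number (0.02 log units; within the scatter) from compound 1 to compound 2 and an at least 5.8-fold higher number (0.76 log units; beyond the scatter) from compound 3 to compound 4, at least 6.1-fold (0.78 log units) apart, beyond the scatter of two such steps
Isopropyl in place of methyl gave an at least 1.8-fold higher number from compound 2 to compound 4 (0.27 log units; that floor lies within the scatter), which is only a floor and leaves the true size of the step unknown, yet it already parts from the earlier step, and the data give no cause for either mismatch: the same change on two cores in this assay, a 3.3-fold lower number (0.51 log units; beyond the scatter) from compound 1 to compound 3 and an at least 1.8-fold higher number (0.27 log units; that floor lies within the scatter) from compound 2 to compound 4, at least 6.1-fold (0.78 log units) apart, beyond the scatter of two such steps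

Still open, as far as these compounds go, is whether chloro or a nitrile on that aromatic carbon would follow the methyl core or the isopropyl core. Equally open, from the compounds shown here alone, is how ethyl or a longer chain on the aromatic nitrogen would behave with each of these aromatic substituents.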